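Adding a trifluoromethyl group on the ring of compound 2

The source may hold more compounds than are shown below. What is called first, only, known or untested is meant among the compounds shown, and "the series" means these compounds.

Measured compounds and their values:
compound 1 `CC1=CCCC(C)(C)C1/C=C/C(=O)/C=C/c1ccc(C(F)(F)F)cc1`, 7900 nM
compound 2 `CC1=C(/C=C/C(=O)/C=C/c2ccccc2)C(C)(C)CCC1O`, 15500 nM
compound 3 `CC1=C(/C=C/C(=O)/C=C/c2ccccc2C(F)(F)F)C(C)(C)CCC1O`, 3700 nM

These three compounds were tested in a functional assay on PC-3 cells (Homo sapiens) for cytotoxicity, read by MTT assay, with a stated time of 72 h; a lower number here means a stronger inhibitor, a higher number a weaker inhibitor. Compound 2 gives the highest number of the three; compound 1 sits closest to it, and the gap between those two lies within the scatter, so no order can be read from them. Compound 3 lies furthest from compound 2, and that gap is beyond the scatter.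

Compound 4 `CC1=C(/C=C/C(=O)/C=C/c2cccc(C(F)(F)F)c2)C(C)(C)CCC1O` is not yet measured. It differs from compound 2 in one place: trifluoromethyl in place of hydrogen on an aromatic carbon.

Among the measured compounds shown here, the only measured step that bears on this change is the one from compound 2 to compound 3, where a trifluoromethyl group likewise replaced a ring hydrogen, though on a different ring carbon: a 4.2-fold lower number from compound 2 to compound 3 (0.62 log units; beyond the scatter). Compound 1 also carries a trifluoromethyl group, but on a different core, so it is not a direct comparison. On that basis a modest drop in number is expected for compound 4, roughly a 2.8-fold lower number from compound 2 to compound 4 (0.45 log units; beyond the scatter) in this assay, though the position differs and the step could be smaller. Compound 4 is therefore estimated at 5500 nM, with a likely range from 2000 nM to 15000 nM.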

Compound 4, half-maximal inhibitory concentration: 3500 nM
Compound 4: middle estimate off by 1.6-fold (0.20 log units), on the high side; the range from low to high includes it.
By their numbers in this assay, from the lowest: compounds 4 and 3 (each within the scatter of the next); then compounds 1 and 2 (each within the scatter of the next).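

In this assay, the drop in number seen earlier with trifluoromethyl on one ring carbon also appears on a second ring carbon: placed meta to a large group, the same swap gives a 4.4-fold lower number from compound 2 to compound 4 (0.65 log units; beyond the scatter), compared with a 4.2-fold lower number from compound 2 to compound 3 (0.62 log units; beyond the scatter) at the earlier position. Compound 3 and compound 4 lie within the scatter of each other, so these two positions cannot be ranked, and among those shown, the gain does not depend on one particular ring carbon. Nothing available here explains why the group lowers the number.

As far as these compounds go, whether a methyl group, an amine or a carboxylic acid on the same ring carbon would give a similar step remains open. So does whether trifluoromethyl would have the same effect on the core of compound 1.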